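Bromo for Fluoro in a Cytotoxic Series

The source may report more compounds than this note shows. Statements on the series, on what has been measured and on what is new or still open speak of the compounds shown alone.

Of the compounds shown here, three built on the shared core have numbers so far in a functional assay on THP-1 cells (Homo sapiens) for cytotoxicity, read by MTT assay, with a stated time of 24 h (on this read-out lower numbers stand for stronger inhibition and higher numbers for weaker inhibition), and compound 1 (`CN1C/C(=C\c2ccc(C(C)(C)C)cc2)C(=O)/C(=C/c2ccccc2F)C1`) gives 13400 nM there. Compound 2 (`CN1C/C(=C\c2ccc(C(F)(F)F)cc2)C(=O)/C(=C/c2ccccc2F)C1`) gives 5930 nM in this assay as well. Compound 3 (`COc1cc(/C=C2\CN(C)C/C(=C\c3ccc(F)cc3)C2=O)cc(OC)c1`) gives 5040 nM and so stands level with compound 2 within the scatter, with both numbers under that of compound 1.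

Compound 4 (`COc1cc(/C=C2\CN(C)C/C(=C\c3ccc(Br)cc3)C2=O)cc(OC)c1`) is compound 3 with bromo in place of fluoro on an aromatic carbon, para to a large group (bromo in place of fluoro on an aromatic carbon). The same difference reads 4-fluorophenyl to 4-bromophenyl.

Among the compounds with values here, only one measured step bears on this change, and only loosely. Trifluoromethyl in place of tert-butyl on an aromatic carbon gave a 2.3-fold lower number from compound 1 to compound 2 (0.35 log units; beyond the scatter) in this assay and counts as modest. That step exchanged other groups, on compounds that also differ from compound 3 elsewhere, and no exchange of fluoro for bromo has been measured here. It therefore gives no direction for the new step.

The expected outcome in this assay is a 1.0-fold lower number from compound 3 to compound 4 (0.00 log units; within the scatter) and so no shift beyond the scatter. Compound 4 is accordingly estimated at 5000 nM with an expected range (2200 nM to 11000 nM).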

Compound 4, half-maximal inhibitory concentration: 4270 nM
Beside the measured number, compound 4's estimate is 1.2-fold (0.07 log units) above it, and the stated range covers the measured number.
By their numbers in this assay, from the lowest: compounds 4, 3 and 2 (each within the scatter of the next); then compound 1.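

Bromo in place of fluoro on an aromatic carbon, para to a large group, gave a 1.2-fold lower number from compound 3 to compound 4 (0.07 log units; within the scatter) in this assay, so in this pair the position accepts either halogen with no shift beyond the scatter. Within the data shown here, the only earlier step exchanged tert-butyl for trifluoromethyl on compounds that also differ from compound 3 elsewhere, whereas this step reads a fluoro-to-bromo exchange directly, and it holds for this one pair alone. No evidence at hand bears on this result.

What the compounds shown leave open is whether a group of another kind at this place, such as an amine, a carboxylic acid or a longer chain, would move the number beyond the scatter, or whether this position stays as undemanding with those groups as it does with the two halogens. Also open, from the compounds shown here alone, is whether 4-fluorophenyl to 4-bromophenyl would read the same on a compound carrying a different group at the other end of the shared core, as compound 1 and compound 2 do.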